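The source may hold more compounds than are shown below. What is called first, only, known or untested is meant among the compounds shown, and "the series" means these compounds.

All the compounds here share one core and differ only in the aromatic group on a carbon with a double bond to nitrogen. In a functional assay on PC-3 cells (Homo sapiens) for cytotoxicity, read by MTT assay, with a stated time of 72 h (a higher number here means a weaker inhibitor, a lower number a stronger inhibitor), compound 1 (`O=C(N/N=C/c1ccc(F)cc1)Nc1cc2c(Nc3ccc(F)c(Cl)c3)ncnc2cc1O[C@H]1CCOC1`) is reported as "not active" (no number reported), with no number given. Compound 2 (`O=C(N/N=C/c1ccc(F)cc1Cl)Nc1cc2c(Nc3ccc(F)c(Cl)c3)ncnc2cc1O[C@H]1CCOC1`) gives 28400 nM, and compound 3 (`O=C(N/N=C/c1cc(Br)c(O)c(Br)c1)Nc1cc2c(Nc3ccc(F)c(Cl)c3)ncnc2cc1O[C@H]1CCOC1`) gives 6160 nM. Among the compounds with values here, that is the lower of the only two numbers available, so compound 3 currently stands as the stronger inhibitor of this measured pair.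

The next compound is compound 4 (`CCN(CC)c1ccc(/C=N/NC(=O)Nc2cc3c(Nc4ccc(F)c(Cl)c4)ncnc3cc2O[C@H]2CCOC2)c(O)c1`), which has not yet been measured in this assay. Its structural change from compound 3 is 4-(diethylamino)-2-hydroxyphenyl in place of 3,5-dibromo-4-hydroxyphenyl on a carbon with a double bond to nitrogen. Both groups hold one six-membered aromatic ring of carbon only, and neither carries a net charge.

Within the data shown here, only one measured step bears on this change: a 4.6-fold lower number from compound 2 to compound 3 (0.66 log units; beyond the scatter). It is modest but beyond the scatter, and it shows that a swap at this place can move the number. It says nothing directly about 4-(diethylamino)-2-hydroxyphenyl, so no clear direction can be drawn from it, and a step beyond the scatter is not expected. The estimated step is a 1.6-fold higher number from compound 3 to compound 4 (0.21 log units; within the scatter). For compound 4, the estimated value is 10000 nM, with an expected range from 3000 nM to 35000 nM.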

Compound 4, half-maximal inhibitory concentration: 4590 nM
Estimate against measurement, compound 4: 2.2-fold (0.34 log units) above, within the range that was stated.
By their numbers in this assay, from the lowest: compounds 4 and 3 (each within the scatter of the next); then compound 2.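

In this assay, replacing 3,5-dibromo-4-hydroxyphenyl with 4-(diethylamino)-2-hydroxyphenyl gives a 1.3-fold lower number from compound 3 to compound 4 (0.13 log units; within the scatter) and this stays within the usual scatter, so this position accepts two quite different groups with no measurable difference, even though one carries bromine and the other a larger nitrogen-bearing substituent. Within the data shown here, the comparison with the 2-chloro-4-fluorophenyl group gives a 6.2-fold lower number from compound 2 to compound 4 (0.79 log units; beyond the scatter) and this lies beyond the scatter, so compound 3 is no longer the only compound clearly separated from compound 2, and both compounds so separated carry a hydroxy group on the ring, which compound 2 lacks. No measurement shown here explains this result.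

With so few compounds, the hydroxy link remains only an observation, and it cannot be separated from the other substituents on those rings; 4-hydroxyphenyl alone and 4-(diethylamino)phenyl would pull those parts apart. From the compounds shown here alone, it is also open how this position would respond to a group of another kind, such as a carboxylic acid or a ring containing nitrogen in place of the carbon-only aromatic ring.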